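Swapping the aromatic side group of compound 3

The source may report more compounds than this note shows. Statements on the series, on what has been measured and on what is new or still open speak of the compounds shown alone.

- Compound 1 `COc1ccccc1OC(C)(C)C1OCC(C/C=C\CCC(=O)O)C(c2cccnc2)O1` gives 224 nM
- Compound 2 `CC(C)(Oc1ccccc1[N+](=O)[O-])C1OCC(C/C=C\CCC(=O)O)C(c2cccnc2)O1` gives 11.2 nM
- Compound 3 `CC(C)(Oc1ccc(F)cc1[N+](=O)[O-])C1OCC(C/C=C\CCC(=O)O)C(c2cccnc2)O1` gives 2.51 nM

These numbers come from a functional assay for inhibition, with Homo sapiens as the target (on this read-out lower numbers stand for tighter binding and higher numbers for weaker binding), and compound 3 has the lowest of the three, with both of its gaps to the others beyond the scatter. Compound 4 `CC(C)(Cc1ccc(F)cc1C#N)C1OCC(C/C=C\CCC(=O)O)C(c2cccnc2)O1` is still unmeasured. The change to it is a group of 10 heavy atoms (8 carbon, 1 nitrogen, 1 fluorine; one six-membered aromatic ring of carbon only) in place of a group of 11 heavy atoms (6 carbon, 1 nitrogen, 3 oxygen, 1 fluorine; one six-membered aromatic ring of carbon only), on a saturated chain carbon bound to two saturated chain carbons and a saturated ring carbon and it touches the whole side group at once.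

The measured steps bear on this only in part. With nitro in place of methoxy there is a large step, a 20-fold lower number from compound 1 to compound 2 (1.30 log units; beyond the scatter) and the two changes together give a large step, an 89-fold lower number from compound 1 to compound 3 (1.95 log units; beyond the scatter) while fluoro in place of hydrogen gives a modest one, a 4.5-fold lower number from compound 2 to compound 3 (0.65 log units; beyond the scatter) so this group clearly matters. Among the measured compounds shown here, compound 4 keeps the fluoro but loses the nitro behind the step of a 20-fold lower number from compound 1 to compound 2 (1.30 log units; beyond the scatter) and no measured step covers such a swap.

What is expected in this assay is a modest rise, a 3.2-fold higher number from compound 3 to compound 4 (0.50 log units; beyond the scatter) and not a fall. For compound 4 the estimate is 8 nM with an expected range from 1.5 nM to 40 nM in this read-out.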

Compound 4, dissociation constant: 2.19 nM
For compound 4 the middle estimate is 3.7-fold (0.56 log units) above the measured one; measured number inside the range.
By their numbers in this assay, from the lowest: compounds 4 and 3 (each within the scatter of the next); then compound 2; then compound 1.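

At this saturated chain carbon, the whole side group can be exchanged while the reading in this assay stays within the scatter (a 1.1-fold lower number from compound 3 to compound 4 (0.06 log units; within the scatter)), even though the entering group holds no oxygen and carries a nitrile instead of a nitro group. Among the compounds shown here, the nitro group and the oxygens of the leaving group are therefore not needed for a low number here, and the new group also stands well clear of the earlier compounds (a 5.1-fold lower number from compound 2 to compound 4 (0.71 log units; beyond the scatter); a 100-fold lower number from compound 1 to compound 4 (2.01 log units; beyond the scatter)). Nothing available explains why these two different groups read alike.

From the compounds shown here alone, it remains open how far the nitrile would hold the number without the fluoro on the same ring. Going by these compounds, how a primary amide in place of the nitrile would read also remains open.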